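The compounds below may be only part of what the source reports. "The series", "measured", "known", "first", "only" and "open" are said of these compounds alone.

Going by the values given here, compound 1, `Cc1ncnc2c1c(I)cn2[C@@H]1O[C@H](CO)[C@@H](O)[C@H]1O`, is the one compound in this set for which a functional assay on HCT-116 cells (Homo sapiens), read by MTT assay, with a stated time of 72 h (on this read-out higher numbers stand for weaker inhibition and lower numbers for stronger inhibition), returns a number: compound 1 gives 7570 nM. The other entry stands at the edge of what this assay can report: compound 2, `COc1nc(N)nc2c1c(-c1ccsc1)cn2[C@@H]1O[C@H](CO)[C@@H](O)[C@H]1O`, gives only > 20000 nM, which is a limit of the assay and not a number, marked by the limit of > 20000 nM in this assay, at which 1 of the 2 values shown sits. Against this background compound 3, `Cc1ncnc2c1c(-c1cccs1)cn2[C@@H]1O[C@H](CO)[C@@H](O)[C@H]1O`, is not yet measured. It differs from compound 1 by thiophen-2-yl in place of iodo on an aromatic carbon. Among the compounds with values here, no measured pair in this set isolates that change, so the expected size of the step rests on the one number available; the step from compound 1 to compound 3 is expected to be a 1.2-fold higher number from compound 1 to compound 3 (0.08 log units; within the scatter), that is, no move beyond the usual scatter in either direction. For compound 3 the estimate in this assay is 9000 nM, with a range from 2500 nM to 20000 nM.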

Compound 3, half-maximal inhibitory concentration: > 20000 nM
Compound 3 gave a limit, no number; the forecaster's own chance of this, stated with the estimate: 30%; at least 2.2-fold (0.34 log units) between middle value and limit.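

At this aromatic carbon of the shared core, the change from iodo to thiophen-2-yl is not neutral in this assay, with an at least 2.6-fold higher number from compound 1 to compound 3 (0.42 log units; beyond the scatter). Going by these compounds alone, this is the first reading that isolates a single change at this position, and compound 3 reports only a limit of the assay, not a number: the limit of > 20000 nM in this assay, at which 2 of the 3 values shown sit. Of the two groups compared at this position, only iodo gives a number, so the position does respond to the group it carries, and the step has a lower bound but no full size.

From the compounds shown here alone, how far compound 3 lies past its limit remains open. Equally open, going by these compounds, is whether an amine, a bromine or a phenyl ring on this carbon would keep a number like that of compound 1 or lose it as thiophen-2-yl does.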